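Trifluoromethyl for methoxy: the expected value of compound 4

This account rests on a few compounds, and the source may have more. Where it says the series, first, only, none or still open, it means among the compounds named here.

Compound 1 `COc1cccc(-c2oc3ccc(NC(C)=O)cc3c(=O)c2O)c1` gives 33300 nM
Compound 2 `CC(=O)Nc1ccc2oc(-c3cccc(C(F)(F)F)c3)c(O)c(=O)c2c1` gives 5700 nM
Compound 3 `COc1cccc(-c2oc3ccc(N)cc3c(=O)c2O)c1` gives 40800 nM

In an ADME assay on MT4 cells (Homo sapiens) for cytotoxicity, read by MTT assay, with a stated time of 4 days (on this read-out lower numbers stand for higher toxicity in this test and higher numbers for lower toxicity in this test), compound 3 stands with compound 1, within the scatter of each other, as a 1.2-fold higher number from compound 1 to compound 3 (0.09 log units; within the scatter) shows, and both numbers lie well clear of compound 2. Compound 4 `Nc1ccc2oc(-c3cccc(C(F)(F)F)c3)c(O)c(=O)c2c1` carries trifluoromethyl in place of methoxy on an aromatic carbon on the ring that held the methoxy in compound 3. The same replacement gave a 5.8-fold lower number from compound 1 to compound 2 (0.77 log units; beyond the scatter) when acetyl sat on the nitrogen. Hydrogen in place of acetyl gave a 1.2-fold higher number from compound 1 to compound 3 (0.09 log units; within the scatter) in the methoxy pair, so a modest fall of similar size is expected here. The expected step is a 5.8-fold lower number from compound 3 to compound 4 (0.77 log units; beyond the scatter) in this read-out. Compound 4 is estimated at 7000 nM and expected to fall between 2800 nM and 17000 nM in this test.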

Compound 4, half-maximal cytotoxic concentration: 8100 nM
Beside the measured number, compound 4's estimate is 1.2-fold (0.06 log units) below it; measured number inside the range.
By their numbers in this assay, from the lowest: compounds 2 and 4 (each within the scatter of the next); then compounds 1 and 3 (each within the scatter of the next).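

In this assay, trifluoromethyl in place of methoxy lowers the number with the nitrogen free as well as acetylated (a 5.0-fold lower number from compound 3 to compound 4 (0.70 log units; beyond the scatter)). Hydrogen in place of acetyl, so far read only in the methoxy pair, also stays within the scatter in the trifluoromethyl pair (a 1.4-fold higher number from compound 2 to compound 4 (0.15 log units; within the scatter)). The step at this aromatic carbon thus holds whichever group sits on the nitrogen in these four compounds: the same change on two cores in this assay, a 5.8-fold lower number (0.77 log units; beyond the scatter) from compound 1 to compound 2 and a 5.0-fold lower number (0.70 log units; beyond the scatter) from compound 3 to compound 4, 1.2-fold (0.06 log units) apart, within the scatter of two such steps.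

The compounds shown leave open how a nitrile or a chlorine on this carbon would read. On these data alone, how a longer acyl chain on the nitrogen would read also remains open.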